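Rat microsomal clearance: from trifluoromethoxy to methylcarbamoyl

The source may report more compounds than this note shows. Statements on the series, on what has been measured and on what is new or still open speak of the compounds shown alone.

Measured in an ADME assay (liver) for pharmacokinetics, with Liver microsome (Rattus norvegicus) as the target, using microsomes; a higher number here means faster removal of the compound, a lower number slower removal:
compound 1 `CNc1nc(NCc2ccc(OC(F)(F)F)cc2)cc(-c2ccccn2)n1` gives > 52.3 mL/min/kg (a limit)
compound 2 `CNc1nc(NCc2ccc(Cl)cc2Cl)cc(-c2ccccn2)n1` gives > 52.3 mL/min/kg (a limit)

Compound 1 reads > 52.3 mL/min/kg in this assay, and this is a limit of the assay, not a number. Compound 2 reads > 52.3 mL/min/kg, which is likewise a limit. Going by the values given here, the only evidence is the limit of > 52.3 mL/min/kg in this assay, at which 2 of the 2 values shown sit, and no measured step is available to scale from.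

Compound 3 `CNC(=O)c1ccc(CNc2cc(-c3ccccn3)nc(NC)n2)cc1` carries methylcarbamoyl in place of trifluoromethoxy on an aromatic carbon, para to a large group: methylcarbamoyl in place of trifluoromethoxy on an aromatic carbon. A downward step of moderate size, beyond the scatter, is expected in this assay, although a result that again reaches the limit remains possible. This expectation rests on the structural change alone. The estimated change is an at least 1.6-fold lower number from compound 1 to compound 3 (0.21 log units; that floor lies within the scatter). For compound 3 the estimated clearance is 32 mL/min/kg, with an expected range of 14 mL/min/kg to 52 mL/min/kg.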

Compound 3, clearance: 31.9 mL/min/kg
For compound 3 the middle estimate is 1.0-fold (0.00 log units) above the measured one; low and high end bracket the measured number.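

In this assay, going by these compounds alone, methylcarbamoyl on the aromatic carbon, para to a large group, gives the first reading that is a number and not a limit: compound 3 reads 31.9 mL/min/kg. Methylcarbamoyl in place of trifluoromethoxy gives an at least 1.6-fold lower number from compound 1 to compound 3 (0.21 log units; that floor lies within the scatter). Compound 1 reads > 52.3 mL/min/kg, which is a limit of the assay, so the step is known only as a floor and its true size cannot be read.

From the compounds shown here alone, it remains open whether the amide hydrogen matters at this place, which dimethylcarbamoyl would test, and whether a nitrile or a carboxylic acid would also give a number and not a limit. Within the data shown here, the effect of changes elsewhere on the shared core also stays open, with compound 3 as the only measured number.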